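Mirror-Image Stereoisomer in a Macrophage Cytotoxicity Series

A few compounds are considered here, and "the series" means these few. Any claim that something is new, unique, unknown or untested is made for them only; others in the source may bear on it.

In an ADME assay on RAW264.7 cells (Mus musculus) for cytotoxicity, read by MTT assay, with a stated time of 24 h (on this read-out lower numbers stand for stronger inhibition and higher numbers for weaker inhibition), the measured compounds give:
Compound 1 `O=C(S[C@]12CC[C@@H](O)[C@H]1C(=O)NC2=O)c1ccc(O)cc1` gives 616000 nM.
Compound 2 `O=C(SC12CCC(O)C1C(=O)NC2=O)c1ccc(O)cc1` gives 434000 nM.
Compound 3 `O=C(S[C@@]12CC[C@@H](O)[C@@H]1C(=O)NC2=O)c1ccc(O)cc1` gives 2910000 nM.

All three share the same atoms and bonds and differ only in how the ring stereocentres are drawn. Compound 3 stands at the highest number of the three, meaning the weakest inhibition: a step of a 4.7-fold higher number from compound 1 to compound 3 (0.67 log units; beyond the scatter) and a step of a 6.7-fold higher number from compound 2 to compound 3 (0.83 log units; beyond the scatter) separate it from the others, while a 1.4-fold lower number from compound 1 to compound 2 (0.15 log units; within the scatter). The change to compound 4 `O=C(S[C@]12CC[C@H](O)[C@H]1C(=O)NC2=O)c1ccc(O)cc1` is the two compounds have the same atoms and bonds and differ only in configuration as drawn: 3 of 3 stereo elements differ (all stereocentres are inverted: mirror images); a stereocentre at a saturated ring carbon is drawn S in compound 3 and R in compound 4; a stereocentre at a saturated ring carbon is drawn R in compound 3 and S in compound 4; a stereocentre at a saturated ring carbon is drawn R in compound 3 and S in compound 4. Among the compounds with values here, the only measured step that alters configuration alone is the one from compound 1 to compound 3, which is attributed to the fact that compounds 1 and 3 differ only in the configuration as drawn and was modest; compound 2, drawn without configuration, also sits well below compound 3. Inverting all three centres is a larger change than either measured step, so a modest fall in number is expected, though with considerable uncertainty. Compound 4 is expected at 900000 nM, ranging from 300000 nM to 3000000 nM. This expectation corresponds to a step of a 3.2-fold lower number from compound 3 to compound 4 (0.51 log units; beyond the scatter).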

Compound 4, half-maximal inhibitory concentration: 1380000 nM
Beside the measured number, compound 4's estimate is 1.5-fold (0.19 log units) below it, within the range that was stated.
By their numbers in this assay, from the lowest: compounds 2 and 1 (each within the scatter of the next); then compound 4; then compound 3.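

The two mirror-image forms are told apart in this assay, with a 2.1-fold lower number from compound 3 to compound 4 (0.32 log units; beyond the scatter), so handedness alone moves the number here: the fact that compounds 3 and 4 differ only in the configuration as drawn. Inverting a single stereocentre is also enough to move the number beyond the scatter, with a 2.2-fold higher number from compound 1 to compound 4 (0.35 log units; beyond the scatter), a shift that rests on configuration alone: the fact that compounds 1 and 4 differ only in the configuration as drawn. The form drawn without any configuration also stands apart from the new compound, with a 3.2-fold higher number from compound 2 to compound 4 (0.50 log units; beyond the scatter): the fact that one of compounds 2 and 4 is drawn with a defined configuration and the other without, at the place where they differ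

Left open is how each of the other two stereocentres acts alone, as no pair shown inverts just one of them. Also open is how the number would respond if a hydroxyl group gave way to an amine or a carboxylic acid, as every compound shown carries the same atoms and bonds.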